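Swapping a Methyl for Fluoro on the Benzyl Arm

The compounds below may be only part of what the source reports. "The series", "measured", "known", "first", "only" and "open" are said of these compounds alone.

Of the compounds shown here, three sharing one core have been tested in a functional assay on CCRF-CEM cells (Homo sapiens) for cytotoxicity, read by cell counting, with a stated time of 3 days; on this read-out lower numbers stand for stronger inhibition and higher numbers for weaker inhibition. Compound 1 `C=C(Br)C(=O)Nc1cccc(/C=C2\SC(=O)N(Cc3ccc(C)cc3)C2=O)c1` gives 1200 nM, the lowest number of the three and therefore the strongest inhibition seen so far. Compound 2 `C=C(Br)C(=O)Nc1ccc(/C=C2\SC(=O)N(Cc3cccc(Cl)c3)C2=O)cc1` gives 3700 nM, a higher number that sits beyond the usual scatter. Compound 3 `CC(C)(C)c1ccc(CN2C(=O)S/C(=C\c3cccc(N)c3)C2=O)cc1` differs from compound 1 in several places. Compound 3 gives 165000 nM, far higher still, so it is by a wide margin the weakest of the three.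

The next compound to be measured is compound 4 `C=C(Br)C(=O)Nc1cccc(/C=C2\SC(=O)N(Cc3ccc(F)cc3)C2=O)c1`. Compared with compound 1, the change is confined to one spot: fluoro in place of methyl on an aromatic carbon. For the measured compounds named here, nothing measured so far isolates the effect of fluoro in place of methyl on an aromatic carbon, so the expectation rests on the change being small and remote from the rest of the molecule. The step of a 1.3-fold higher number from compound 1 to compound 4 (0.10 log units; within the scatter) is expected to stay within the scatter, with no clear direction. Compound 4 is thus estimated at 1500 nM, likely between 600 nM and 4000 nM.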

Compound 4, half-maximal inhibitory concentration: 680 nM
The estimate for compound 4 lay 2.2-fold (0.34 log units) above the measured number, within the range that was stated.
By their numbers in this assay, from the lowest: compounds 4 and 1 (each within the scatter of the next); then compound 2; then compound 3.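

For the compounds shown here, the step of a 1.8-fold lower number from compound 1 to compound 4 (0.25 log units; within the scatter) gives the first direct reading of this change. In this assay the swap of methyl for fluoro, on the aromatic carbon para to a large group, leaves compound 1 and compound 4 indistinguishable, so at this spot the methyl is not required to keep the number at this level. Nothing measured here offers an explanation for this outcome.

On these data alone, with only methyl and fluoro compared at this spot, it remains open whether an amine, a methoxy group or a longer chain such as propyl would keep the number at this level or move it clearly. As far as these compounds go, it also remains open whether a fluoro on another carbon of the same ring would behave as it does here.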